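The compounds below may be only part of what the source reports. "The series", "measured", "known", "first", "only" and "open" are said of these compounds alone.

Compound 1 `COc1cc(NC(C)CCCNC(=O)Nc2cccc(F)c2)c2ncccc2c1` gives the highest of the two numbers shown in a functional assay on HeLa cells (Homo sapiens) for inhibition, read by MTT assay, with a stated time of 72 h (on this read-out lower numbers stand for stronger inhibition and higher numbers for weaker inhibition), where compound 1 reaches 18000 nM. For the measured compounds named here, its nearest neighbour is compound 2 `COc1cc(NC(C)CCCNC(=O)Nc2ccc(C(F)(F)F)cc2)c2ncccc2c1`, which in this assay gives 8300 nM; the single measured step is a 2.2-fold lower number from compound 1 to compound 2 (0.34 log units; beyond the scatter), a modest change beyond the scatter. Compound 3 `COc1cc(NC(C)CCCNC(=O)Nc2ccc(Cl)cc2)c2ncccc2c1` has not yet been measured. It differs from compound 1 by 4-chlorophenyl in place of 3-fluorophenyl on an amide-type nitrogen. Going by the values given here, only one measured step bears on this change, and it is the one from compound 1 to compound 2, where a different group entered in the same place on the amide-type nitrogen and the number fell modestly. No direct comparison of 4-chlorophenyl against either of the other groups exists here, so the expectation rests on that single step alone. Compound 3 is therefore expected to give about 10000 nM in this assay, within a range from 4000 nM to 25000 nM. The expected change is a 1.8-fold lower number from compound 1 to compound 3 (0.26 log units; within the scatter), a small improvement that may not clear the scatter.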

Compound 3, half-maximal inhibitory concentration: 18000 nM
Compound 3: the middle estimate sits 1.8-fold (0.26 log units) below what was measured; measured number inside the range.
By their numbers in this assay, from the lowest: compound 2; then compounds 1 and 3 (each within the scatter of the next).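

In this assay, 4-chlorophenyl in place of 3-fluorophenyl on the amide-type nitrogen gives no change at the digits printed from compound 1 to compound 3 (within the scatter), so this replacement leaves the number where it was. Chloro in place of trifluoromethyl on an aromatic carbon gives a 2.2-fold higher number from compound 2 to compound 3 (0.34 log units; beyond the scatter), which shows that the lower number of compound 2 does not carry over to every 4-substituted phenyl group; compound 3 goes against any such reading. No measurement shown here explains these differences.

Going by these compounds, the three compounds vary only the substituted phenyl group, so it remains open whether an amine or a carboxylic acid on that ring would lower the number. Also open, on these data alone, is how a longer chain on the shared core would affect it, since the chain is the same in all three compounds.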